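Nitro-to-methoxy swap on the triazole aryl group

The compounds below may be only part of what the source reports. "The series", "measured", "known", "first", "only" and "open" are said of these compounds alone.

For the measured compounds named here, in a functional assay on the whole organism (strain Wistar) with Rattus norvegicus as the target, with a stated time of 15 days, at a dose of 100 mg/kg by the oral route (a lower number here means a weaker effect, a higher number a stronger effect of the compound at the dose given), compound 3 `O=C1NC(=O)/C(=C/c2ccc(OCCSc3nnc(-c4ccccc4[N+](=O)[O-])[nH]3)cc2)S1` gives 49.1%, the highest of the three numbers so far. Compound 1 `O=C1NC(=O)/C(=C/c2ccc(OCCSc3nnc(Cc4ccccc4)[nH]3)cc2)S1` gives 41.9%, and a number 7.2 percentage points higher from compound 1 to compound 3 (within the scatter). Compound 2 `O=C1NC(=O)/C(=C/c2ccc(OCCSc3nnc(-c4ccc([N+](=O)[O-])cc4)[nH]3)cc2)S1` gives 22.1%, and a number 27 percentage points higher from compound 2 to compound 3 (beyond the scatter). Compound 4 `COc1ccc(-c2nnc(SCCOc3ccc(/C=C4\SC(=O)NC4=O)cc3)[nH]2)cc1` carries the change (4-methoxyphenyl in place of 2-nitrophenyl on an aromatic carbon). Going by the values given here, the steps that bear on it both touch the same aromatic carbon: a number 19.8 percentage points lower from compound 1 to compound 2 (beyond the scatter), while a number 27 percentage points higher from compound 2 to compound 3 (beyond the scatter). Among the compounds with values here, no measured step involves a 4-methoxyphenyl, so the expectation rests only on the 4-nitrophenyl of compound 2 being the low point. A modest loss is expected, a number 14.1 percentage points lower from compound 3 to compound 4 (beyond the scatter), possibly still within the scatter. Compound 4 is estimated at 35%, with a range of 15% to 55%.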

Compound 4, a percentage reported as activity, at one dose (the size of the read-out at that dose, not a potency): 71.2%
For compound 4 the middle estimate is 36.2 percentage points below the measured one, and the stated range ends below it.
By their numbers in this assay, from the lowest: compound 2; then compounds 1 and 3 (each within the scatter of the next); then compound 4.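

At this aromatic carbon of the five-membered ring, 4-methoxyphenyl gives the highest read-out of the series in this assay, with a number 22.1 percentage points higher from compound 3 to compound 4 (beyond the scatter) and a number 29.3 percentage points higher from compound 1 to compound 4 (beyond the scatter) as its steps from the 2-nitrophenyl and benzyl groups. The largest step, a number 49.1 percentage points higher from compound 2 to compound 4 (beyond the scatter), keeps the substituent at the same ring position, so a 4-substituted phenyl group is not low in itself: the outcome here depends on which substituent it carries. Nothing available explains this rise.

Going by these compounds, whether a 4-hydroxyphenyl or 4-aminophenyl group would stay near the level of compound 4 remains open. A 2-methoxyphenyl group would show whether the methoxy gain holds at the other ring position.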